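The compounds below may be only part of what the source reports. "The series", "measured", "known", "first", "only" and "open" are said of these compounds alone.

Measured in a functional assay on A549 cells (Homo sapiens) for cytotoxicity, read by MTT assay, with a stated time of 24 h; a lower number here means a stronger inhibitor, a higher number a weaker inhibitor:

Compound 1 `C=C1C(=O)[C@@]23C[C@@H]1CC[C@@H]2[C@@]1(C)CCCC(C)(C)[C@@H]1COC3=O`: 2300 nM
Compound 2 `CCOC1C=C(CC[C@]2(C)[C@@H](C)CC[C@@]3(C)C(C(=O)O)=CC=C[C@@H]23)C(=O)O1`: > 40000 nM (a limit, not a number)
Compound 3 `C=C1CC[C@H](C)[C@@](C)(CCC2=CC(OCC)OC2=O)C/C=C\C=C/1C(=O)O`: > 40000 nM (a limit, not a number)

Compound 3 gives no number in this assay, only the limit > 40000 nM. It shares this position with compound 2, and the set as a whole shows (the limit of > 40000 nM in this assay, at which 2 of the 3 values shown sit). Among the measured compounds shown here, compound 1 is the only one with a numerical value.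

Compound 4 `C=C1CC[C@H](C)[C@@](C)(CCC2=CC(OC)OC2=O)C/C=C\C=C/1C(=O)O` has not yet been measured. It differs from compound 3 in one place: hydrogen in place of methyl on a saturated chain carbon bound to an oxygen on a saturated carbon. In words, hydrogen stands in place of methyl on a saturated chain carbon bound to an oxygen on a saturated carbon, which turns ethoxy into methoxy. For the measured compounds named here, no measured pair shows what this change does, so no step beyond the scatter is expected in this assay, in either direction. This expectation rests on compound 3, whose > 40000 nM is a limit. The expected step is a number no higher from compound 3 to compound 4 (the limit leaves the size open). Compound 4 is therefore expected to remain at the limit, with an estimated value of 40000 nM, in an expected range from 15000 nM to 80000 nM.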

Compound 4, half-maximal inhibitory concentration: > 40000 nM
Compound 4: a limit, no number (the forecaster's own chance of this, stated with the estimate: 75%); the middle value sits exactly at the limit.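

Compound 3 and compound 4 both give only a limit, not a number, in this assay, and no step between them can be read: the limit of > 40000 nM in this assay, at which 3 of the 4 values shown sit.

The compounds shown leave open what the change from ethoxy to methoxy does to the value in this assay.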